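Compound 1 to compound 4: methyl in place of methoxy

This account rests on a few compounds, and the source may have more. Where it says the series, first, only, none or still open, it means among the compounds named here.

In a functional assay on OE21 cells (Homo sapiens) for cytotoxicity, read by MTT assay, with a stated time of 72 h (on this read-out lower numbers stand for stronger inhibition and higher numbers for weaker inhibition), compound 1 (`COc1ccc2[nH]c(-c3ccc[nH]3)c(C3CC(=O)NC3=O)c2c1`) gives 53000 nM and compound 2 (`COc1ccc2[nH]c(-c3ccc[nH]3)cc2c1`) gives 33000 nM. Among the compounds with values here, these are the only two numbers, and they stand within the scatter of each other. Compound 3 (`COc1ccc2[nH]c3c(c4c(n5cccc35)C(=O)N(C)C4=O)c2c1`) reads > 100000 nM, which is a limit of the assay and not a number.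

Compound 4 (`Cc1ccc2[nH]c(-c3ccc[nH]3)c(C3CC(=O)NC3=O)c2c1`) differs from compound 1 by methyl in place of methoxy on an aromatic carbon. Within the data shown here, no measured step touches the methoxy. Among the measured compounds shown here, the one measured step, a 1.6-fold lower number from compound 1 to compound 2 (0.21 log units; within the scatter), changes another group on compound 1 and gives only weak guidance. No step beyond the scatter is therefore expected in this assay. The estimated change is a 1.2-fold lower number from compound 1 to compound 4 (0.07 log units; within the scatter). For compound 4 the expected value is 45000 nM, with an estimated range of 18000 nM to 100000 nM.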

Compound 4, half-maximal inhibitory concentration: > 100000 nM
Compound 4 was reported as a limit; the forecaster's own chance of this, stated with the estimate: 15%; middle value at least 2.2-fold (0.34 log units) from the limit.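

In this assay, the methoxy position now has its first measured change, and methyl in place of methoxy gives an at least 1.8-fold higher number from compound 1 to compound 4 (0.27 log units; that floor lies within the scatter). Compound 4 reads > 100000 nM, which is a limit of the assay and not a number. This is the only single change shown that takes the core of compound 1 to that limit: the limit of > 100000 nM in this assay, at which 2 of the 4 values shown sit.

As far as these compounds go, whether methoxy at this aromatic carbon can be told apart from methyl by a step beyond the scatter stays open. So does what an amine or a hydroxyl group would read there.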